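The source may hold more compounds than are shown below. What is called first, only, known or untested is meant among the compounds shown, and "the series" means these compounds.

Measured so far:
compound 1, `CC(C)(N)C(=O)N[C@H](COCc1ccccc1)c1nnnn1Cc1ccc(NS(C)(=O)=O)cc1`: > 5000 nM
compound 2, `CC(C)(N)C(=O)N[C@H](COCc1ccccc1)c1nnnn1CCCc1ccccc1`: 200 nM

Among the measured compounds shown here, in an assay on isolated protein for displacement of a labelled ligand from growth hormone secretagogue receptor type 1 (Homo sapiens), with a stated time of 1 h (on this read-out higher numbers stand for weaker inhibition and lower numbers for stronger inhibition), compound 2 gives 200 nM, the only number in the set. In this assay compound 1 gives > 5000 nM, a limit and not a number. For the measured compounds named here, the one measured step, an at least 25-fold lower number from compound 1 to compound 2 (1.39 log units; beyond the scatter), put phenethyl in place of 4-(methanesulfonamido)phenyl on the chain carbon bound to the aromatic nitrogen. Compound 3, `CN(c1ccccc1CCCn1nnnc1[C@@H](COCc1ccccc1)NC(=O)C(C)(C)N)S(C)(=O)=O`, differs from compound 2 by methyl(methylsulfonyl)amino in place of hydrogen on an aromatic carbon. Given the size of an at least 25-fold lower number from compound 1 to compound 2 (1.39 log units; beyond the scatter) when a methanesulfonamido-bearing ring was removed, a weaker number is expected on return of a related group, with a 3.0-fold higher number from compound 2 to compound 3 (0.48 log units; beyond the scatter) taken as moderate. Compound 3 is estimated at 600 nM, between 150 nM and 3000 nM.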

Compound 3, inhibition constant: 1720 nM
Estimate against measurement, compound 3: 2.9-fold (0.46 log units) below; the measured number falls inside the stated range.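

In this assay, adding methyl(methylsulfonyl)amino on an aromatic carbon, ortho to a large group, carries a real cost: an 8.6-fold higher number from compound 2 to compound 3 (0.93 log units; beyond the scatter). On this chain the added group weakens the read-out but still leaves a measurable number for compound 3. Compound 1 remains a limit and not a number: the limit of > 5000 nM in this assay, at which 1 of the 3 values shown sits.

Open, on these data alone, is whether the cost follows this position or this group. A methoxy group or a free amine on the same carbon would separate the two, and the compounds shown do not tell.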